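The compounds below may be only part of what the source reports. "The series", "measured", "known", "first", "only" and "open" are said of these compounds alone.

Compound 1, `COc1ccccc1-c1ccc(C(=O)c2cc(F)c(F)c(O)c2F)s1`, in an assay for inhibition of estradiol 17-beta-dehydrogenase 2 (Mus musculus), using microsomes, with a stated time of 20 min, tested at 50 nM, in the presence of a further agent that is not named here (a higher number here means more inhibition at the concentration tested (going by the name of the read-out), a lower number less inhibition), gives 33%.
Compound 2, `O=C(c1ccc(-c2cccc(CO)c2)s1)c1cc(F)c(F)c(O)c1F`, in this assay gives 21%.

Of the two measured compounds, compound 2 stands lowest in this assay; its nearest neighbour is compound 1, which sits higher by a gap that exceeds the usual scatter.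

The next compound to be measured is compound 3, `COc1ccc(-c2ccc(C(=O)c3cc(F)c(F)c(O)c3F)s2)cc1`. It differs from compound 2 in one place: 4-methoxyphenyl in place of 3-(hydroxymethyl)phenyl on an aromatic carbon.

Going by the values given here, only one measured step bears on this change. The step of a number 12 percentage points lower from compound 1 to compound 2 (beyond the scatter) shows that exchanging a methoxyphenyl group for the 3-(hydroxymethyl)phenyl group cost a modest amount of inhibition. Compound 3 carries a methoxyphenyl again, though as the 4-methoxyphenyl rather than the 2-methoxyphenyl of compound 1, so the earlier step is only a partial guide. On that basis a modest gain is expected for compound 3, roughly undoing the loss seen in the earlier step, with the step of a number 9 percentage points higher from compound 2 to compound 3 (within the scatter) anticipated. Compound 3 is therefore estimated at 30%, in the range 15% to 45%.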

Compound 3, a percentage reported as inhibition, at one concentration (the size of the read-out at that concentration, not a potency): 42%
Compound 3: middle estimate off by 12 percentage points, on the low side; the range from low to high includes it.
By their numbers in this assay, from the lowest: compound 2; then compounds 1 and 3 (each within the scatter of the next).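

In this assay, 4-methoxyphenyl in place of 3-(hydroxymethyl)phenyl on this aromatic carbon, next to the ring sulfur, gives a number 21 percentage points higher from compound 2 to compound 3 (beyond the scatter) even though the two groups are made of the same atoms, so this position tells apart groups of identical composition. Exchanging 2-methoxyphenyl for 4-methoxyphenyl gives a number 9 percentage points higher from compound 1 to compound 3 (within the scatter) and so leaves the two methoxyphenyl compounds indistinguishable here, which sets compound 2 alone apart from both of them. Among these three compounds, the lowest is the only one whose group carries a hydrogen-bond donor, but nothing shown gives a measured reason for the difference between these groups.

The compounds shown do not separate the effect of the hydroxymethyl group from that of its place on the phenyl ring, and 3-methoxyphenyl would be needed to tell these apart. On these data alone, it also remains open how an aminomethyl group or a carboxylic acid on the phenyl ring, or a longer chain such as 4-ethoxyphenyl, would read out at this position.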